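Swapping a thioamide for a carbamoyl on one shared core

A few compounds are considered here, and "the series" means these few. Any claim that something is new, unique, unknown or untested is made for them only; others in the source may bear on it.

Of the compounds shown here, three built on the same core have been tested in a functional assay on cells (kidney, Cercopithecidae) for cytotoxicity; a lower number here means a stronger inhibitor, a higher number a weaker inhibitor. Compound 1 `CC(=O)OCCOCn1nc(C#N)c2c(N)ncnc21` gives only a limit in this assay, > 100000 nM. Compound 2 `COC(=N)c1nn(COCCO)c2ncnc(N)c12` likewise reaches no number but a limit, > 100000 nM. Among the measured compounds shown here, compound 3 `NC(=S)c1nn(COCCO)c2ncnc(N)c12` is the only one with an actual number: in this assay compound 3 gives 100000 nM. For the measured compounds named here, the single measured step, a number no higher from compound 2 to compound 3 (the limit leaves the size open), cannot be sized because its starting point is the limit of > 100000 nM in this assay, at which 2 of the 3 values shown sit. Compound 4 `NC(=O)c1nn(COCCO)c2ncnc(N)c12` differs from compound 3 in one spot: a group of 3 heavy atoms (1 carbon, 1 nitrogen, 1 oxygen; no ring) in place of a group of 3 heavy atoms (1 carbon, 1 nitrogen, 1 sulfur; no ring), on an aromatic carbon. Going by the values given here, no measured step tells how such an exchange shifts this assay, and the one step that exists is open-ended, so nothing points to a change beyond the scatter. Compound 4 is therefore expected at 100000 nM, with a range of 40000 nM to 300000 nM, and a good chance that this assay again reports only a limit. The estimated step of no change at the digits printed from compound 3 to compound 4 (within the scatter) thus amounts to no movement beyond the scatter.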

Compound 4, half-maximal inhibitory concentration: > 100000 nM
Compound 4 was reported as a limit; the forecaster's own chance of this, stated with the estimate: 65%; the middle value lies on the limit itself.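

At this aromatic carbon, exchanging the thioamide for a carbamoyl gives a number no lower from compound 3 to compound 4 (the limit leaves the size open) in this assay. Across the three groups shown on this carbon, including the one in compound 2, none gives a lower number than compound 3 at 100000 nM. Compound 4 gives only a limit, so neither of its two new steps can be sized: the limit of > 100000 nM in this assay, at which 3 of the 4 values shown sit.

On these data alone, how far compound 2 and compound 4 lie past their limits stays open, and so does the true size of the sulfur-to-oxygen exchange. As far as these compounds go, it is also open whether a carboxylic acid or an amine on this carbon, or a longer chain in place of the (2-hydroxyethoxy)methyl group, would give a clearly lower number in this assay.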